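Ester in place of amide on the carbonyl of compound 1

The source may hold more compounds than are shown below. What is called first, only, known or untested is meant among the compounds shown, and "the series" means these compounds.

Measured so far:
compound 1 `CC1=C(C(=O)NC(C)C)C(c2ccco2)NC(=O)N1` — 3%
compound 2 `CC1=C(C(=O)NC(C)C)C(c2cccs2)NC(=O)N1` — 2%
compound 3 `CC1=C(c2ncc(C)o2)C(c2ccco2)NC(=O)N1` — 27%

All three numbers come from an assay on membranes from CHO cells for displacement of a labelled ligand from adenosine receptor A1 (Homo sapiens), read by scintillation counting, with a stated time of 60 min, tested at 1 uM; on this read-out lower numbers stand for less inhibition and higher numbers for more inhibition at the one concentration tested (going by the name of the read-out). Compound 1 stands second highest of the three. Its nearest neighbour is compound 2, where the change on the saturated ring carbon gives a number 1 percentage points lower from compound 1 to compound 2 (within the scatter). The furthest is compound 3, where the isopropylcarbamoyl on the double-bonded ring carbon is exchanged for an oxazolyl group, giving a number 24 percentage points higher from compound 1 to compound 3 (beyond the scatter).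

Compound 4 `CC1=C(C(=O)OC2CCC2)C(c2ccco2)NC(=O)N1` is not yet measured in this assay. It differs from compound 1 as follows: cyclobutyloxy in place of isopropylamino on a carbonyl carbon. The change sits on the carbonyl carbon attached to the double-bonded ring carbon, so it alters the same group that the step to compound 3 replaced outright, while keeping the carbonyl in place. The step to compound 2, on the other ring carbon, does not touch this position and was within the scatter. Within the data shown here, only one step therefore bears on the present change, and it replaced the whole group rather than its amine part; no measured pair shows an ester against an amide. The expectation is a small step, a number 4 percentage points higher from compound 1 to compound 4 (within the scatter), which may well remain within the scatter. Compound 4 is estimated at 7%, with a range from -6% to 24%.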

Compound 4, a percentage reported as inhibition, at one concentration (the size of the read-out at that concentration, not a potency): 19%
For compound 4 the middle estimate is 12 percentage points below the measured one; the measured number falls inside the stated range.
By their numbers in this assay, from the lowest: compounds 2 and 1 (each within the scatter of the next); then compounds 4 and 3 (each within the scatter of the next).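

In this assay, among these compounds, the step of a number 16 percentage points higher from compound 1 to compound 4 (beyond the scatter) is the first sign that this position responds while the carbonyl stays in place, so replacing the whole group, as in compound 3, is not the only change here that lifts the number beyond the scatter. Compound 4 at 19% and compound 3 at 27% lie within the scatter of each other, so two quite different groups on this ring carbon give readings that cannot be told apart in this series. Nothing available accounts for the step, which stands as an observation only.

The exchange alters the linking atom and the carbon group together, as the amide hydrogen and the isopropyl leave and the oxygen and the cyclobutyl ring enter, so the compounds shown cannot separate the two parts; an isopropyl ester or a cyclobutyl amide on the same carbonyl would do so. Also open, on these data alone, is whether the cyclobutyloxy carbonyl behaves the same with thiophen-2-yl in place of furan-2-yl on the saturated ring carbon, and what a carboxylic acid or a longer alkyl chain on the ester oxygen would give.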